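The compounds below may be only part of what the source reports. "The series", "measured", "known", "first", "only" and "open" are said of these compounds alone.

Measured in a functional assay (aorta) with Oryctolagus cuniculus as the target; a lower number here means tighter binding, a higher number weaker binding:
compound 1, `COc1cc(C(C)=O)ccc1OCCCN1CCC(C(c2ccccc2)c2ccccc2)CC1`: 6.31 nM
compound 2, `CC(=O)c1ccc(OCCCN2CCC(C(c3ccc(F)cc3)c3ccc(F)cc3)CC2)cc1`: 2.51 nM
compound 3, `Fc1ccc(C(c2ccc(F)cc2)C2CCN(CCCOc3ccc(Cl)cc3)CC2)cc1`: 2 nM

Compound 3 has the lowest of the three numbers in this assay. Going by the values given here, compound 2 is its nearest neighbour, and the only single-point step on record, a 1.3-fold lower number from compound 2 to compound 3 (0.10 log units; within the scatter), stays within the scatter. Compound 1 is the furthest away, and the gap between compound 1 and compound 3 is beyond the scatter, though the two differ in more than one place, so no single step can be read from that pair.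

Compound 4, `Fc1ccc(C(c2ccc(F)cc2)C2CCN(CCCOc3ccccc3)CC2)cc1`, is not yet measured. It differs from compound 3 in one place: hydrogen in place of chloro on an aromatic carbon. The step on record that bears on it is the one at the same aromatic carbon, from compound 2 to compound 3, which exchanged one substituent for another without moving beyond the scatter. Nothing in the series removes a substituent from that carbon altogether, so the present change is only loosely covered. On that basis no step beyond the scatter is expected in this assay, with a slight lean toward a higher number. Compound 4 is expected to give 3.2 nM, estimated between 1.2 nM and 8.5 nM. The estimated step is a 1.6-fold higher number from compound 3 to compound 4 (0.20 log units; within the scatter).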

Compound 4, dissociation constant: 1.59 nM
For compound 4 the middle estimate is 2.0-fold (0.30 log units) above the measured one; measured number inside the range.
By their numbers in this assay, from the lowest: compounds 4, 3 and 2 (each within the scatter of the next); then compound 1.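

In this assay, the series now holds a case with no substituent at all on this aromatic carbon, para to a large group: hydrogen in place of chloro gives a 1.3-fold lower number from compound 3 to compound 4 (0.10 log units; within the scatter), and hydrogen in place of acetyl gives a 1.6-fold lower number from compound 2 to compound 4 (0.20 log units; within the scatter). Both steps stay within the scatter, as does the earlier exchange of substituents, a 1.3-fold lower number from compound 2 to compound 3 (0.10 log units; within the scatter), so acetyl, chloro and hydrogen at this carbon cannot be told apart in this assay, and among compound 2, compound 3 and compound 4 neither substituent is needed for a number in this range. No measurement on hand bears on why these three compounds lie so close together.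

Going by these compounds, this reading covers only acetyl, chloro and hydrogen, so it remains open whether an amine, a carboxylic acid or a methoxy group alone at this carbon would also stay within the scatter of compound 4. Going by these compounds alone, also open are a longer chain between the phenoxy group and the shared core, and the separate contribution of the two fluoro groups, which no single-place step involving compound 1 can isolate.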